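This account rests on a few compounds, and the source may have more. Where it says the series, first, only, none or still open, it means among the compounds named here.

Among the measured compounds shown here, compound 3, with the structure `c1ccc(-c2nc[nH]n2)c(NCC2=NCCN2)c1`, gives the only plain number in this small set. In an in vitro functional assay on cells (Fibroblast) for agonist activity at Alpha-1B adrenergic receptor (Homo sapiens) (on this read-out higher numbers stand for an effect only at larger amounts of compound and lower numbers for an effect already at smaller amounts), compound 3 gives 5.01 nM. Two companions sit beside it. Compound 1, with the structure `Cn1nccc1-c1ccccc1NCC1=NCCN1`, gives in this assay < 100000 nM, which is a limit and not a number. Compound 2, with the structure `CCn1cccc1-c1ccccc1NCC1=NCCN1`, gives in this assay < 100000 nM, likewise a limit and not a number. For the measured compounds named here, the one measured step touching compound 3, a step that the limit leaves unreadable from compound 1 to compound 3, cannot be sized because the limit of < 100000 nM in this assay, at which 2 of the 3 values shown sit, hides the starting point, so compound 3 stands alone as the only readable point, with nothing above or below it that can be compared.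

The compound not yet measured is compound 4, with the structure `c1ccc(-c2cn[nH]c2)c(NCC2=NCCN2)c1`. It differs from compound 3 by the change (1H-pyrazol-4-yl in place of 1H-1,2,4-triazol-3-yl on an aromatic carbon). Going by the values given here, no measured step shows what this change does, since the step from compound 1 to compound 3 is unreadable and compound 2 is also a limit. The expectation therefore rests on compound 3 alone, with a wide range allowed around it. Compound 4 is expected to give in this assay 15 nM, with a range from 2 nM to 150 nM, which means an expected step of a 3.0-fold higher number from compound 3 to compound 4 (0.48 log units; beyond the scatter) that may well fall within the scatter.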

Compound 4, half-maximal effective concentration: 79.4 nM
Compound 4: the middle estimate sits 5.3-fold (0.72 log units) below what was measured, and the stated range covers the measured number.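

In this assay, among the compounds shown here, the replacement of 1H-1,2,4-triazol-3-yl by 1H-pyrazol-4-yl gives the first readable step at this place, on an aromatic carbon ortho to a group of 7 heavy atoms: a 16-fold higher number from compound 3 to compound 4 (1.20 log units; beyond the scatter). The two groups are both five-membered aromatic rings of 5 heavy atoms with 1 hydrogen-bond donor and no net charge, yet the entering group has 3 carbon and 2 nitrogen atoms and 1 hydrogen-bond acceptor where the leaving group has 2 carbon and 3 nitrogen atoms and 2 hydrogen-bond acceptors, so the read-out at this place responds strongly to a change that leaves ring size and donor count as they were. The step from compound 1 to compound 4 cannot be read, because compound 1 gives a limit and not a number: the limit of < 100000 nM in this assay, at which 2 of the 4 values shown sit.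

The two readable groups differ both in their ring atoms and in the ring atom that carries the bond to the core, so the compounds shown do not separate these two differences. On these data alone, how a 1H-imidazol-2-yl, a tetrazole, an amide or a carboxylic acid would read at this place remains open.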